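The source may hold more compounds than are shown below. What is called first, only, known or untested is meant among the compounds shown, and "the series" means these compounds.

This account follows the step from compound 2 to compound 4 in a functional assay on SK-BR-3 cells (Homo sapiens) for antiproliferative activity, read by MTT assay, with a stated time of 72 h; on this read-out lower numbers stand for stronger inhibition and higher numbers for weaker inhibition. Compound 2 `C/C=C1/[C@H](O[C@@H]2O[C@H](COC(C)=O)[C@@H](OC(C)=O)[C@H](OC(C)=O)[C@H]2OC(C)=O)OC=C(C(=O)OC)[C@H]1CC(=O)O` gives only a limit of this assay, > 15000 nM. Compound 1 `C/C=C1/[C@H](O[C@@H]2O[C@H](COC(C)=O)[C@@H](OC(C)=O)[C@H](OC(C)=O)[C@H]2OC(C)=O)OC=C(C(=O)O)[C@H]1CC(=O)O` likewise gives only a limit, > 20000 nM. Compound 3 `C/C=C1/[C@H](O[C@@H]2O[C@H](CO)[C@@H](O)[C@H](O)[C@H]2O)OC=C(C(=O)OC)[C@H]1CC(=O)OCC` also returns a limit, > 15000 nM. Compound 2 therefore stands together with the other two compounds at the edge of what this assay can report; the values shown are bounded by the limit of > 15000 nM in this assay, at which 2 of the 3 values shown sit, and by the limit of > 20000 nM in this assay, at which 1 of the 3 values shown sits. Compound 4 `C=C(C)CCOC(=O)C[C@@H]1C(C(=O)OC)=CO[C@@H](O[C@@H]2O[C@H](COC(C)=O)[C@@H](OC(C)=O)[C@H](OC(C)=O)[C@H]2OC(C)=O)/C1=C/C` differs from compound 2 by a single change: 3-methylbut-3-en-1-yl in place of hydrogen on an oxygen next to a carbonyl group. Among the measured compounds shown here, only one measured step concerns the same oxygen next to a carbonyl group, and it gives no size because a step that the two limits leave unreadable from compound 1 to compound 2 runs between two limits. Nothing measured points to a readable change in this assay, and compound 4 is expected most likely to return a limit as well, with the step that the limit leaves unreadable from compound 2 to compound 4 expected to stay within the scatter. Compound 4 is estimated at 20000 nM, with a range from 8000 nM to 50000 nM, and the chance that the assay again reports no number is judged high.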

Compound 4, half-maximal inhibitory concentration: > 15000 nM
Compound 4 was reported as a limit; the forecaster's own chance of this, stated with the estimate: 75%; the middle value lies beyond the limit too.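

Compound 4 returns only a limit in this assay, > 15000 nM. Compound 2 also stands at a limit, so no step can be read from compound 2 to compound 4. The compounds shown leave open whether 3-methylbut-3-en-1-yl in place of hydrogen changes the inhibition at all, since none of them gives a readable number in this assay.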